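A few compounds are considered here, and "the series" means these few. Any claim that something is new, unique, unknown or untested is made for them only; others in the source may bear on it.

Measured in an ADME assay on a cell-free system (plasma, Rattus norvegicus) for protein binding; a higher number here means a larger unbound share of the compound, a lower number a smaller unbound share:
compound 1 `N#Cc1ccc(O[C@H]2CN(S(=O)(=O)c3ccc(Cl)cc3Cl)C[C@]2(O)CO)cc1F` gives 0.04
compound 2 `N#Cc1ccc(O[C@H]2CN(S(=O)(=O)c3ccccc3C#N)C[C@@]2(O)CO)cc1F` gives 0.197

Compound 2 holds the higher of the two numbers, and its gap to compound 1 lies beyond the scatter. Compound 3 `N#Cc1ccc(O[C@H]2CN(S(=O)(=O)c3ccc(Cl)cc3)C[C@@]2(O)CO)cc1F` has not yet been measured. It differs from compound 2 as follows: 4-chlorophenyl in place of 2-cyanophenyl on a sulfonyl sulfur; in words, 4-chlorophenyl in place of 2-cyanophenyl on a sulfonyl sulfur. Among the compounds with values here, no measured pair isolates this change, and two compounds establish no pattern. Within the data shown here, the sole guide is compound 1, whose group on the sulfonyl sulfur also bears chlorine and whose 0.04 sits at the low end. A fall is therefore expected, with an estimated 2.5-fold lower number from compound 2 to compound 3 (0.39 log units; beyond the scatter) that lies modestly beyond the scatter. In this assay the estimate for compound 3 is 0.08 with an expected range from 0.04 to 0.15.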

Compound 3, unbound fraction: 0.035
The estimate for compound 3 lay 2.3-fold (0.36 log units) above the measured number; measured number below the stated range.
By their numbers in this assay, from the lowest: compounds 3 and 1 (each within the scatter of the next); then compound 2.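

With the shared core held constant, the group on a sulfonyl sulfur whose other neighbour is the sulfonamide nitrogen in a ring now has a direct reading in this assay: 4-chlorophenyl in place of 2-cyanophenyl gives a 5.6-fold lower number from compound 2 to compound 3 (0.75 log units; beyond the scatter). Within the data shown here, this is the first single-place comparison, and it shows that this position alone can move the unbound fraction beyond the scatter, which the comparison of compound 1 with compound 2 could not show. No measurement available here explains the step.

The swap replaces the nitrile with chlorine and also changes the substituent's place on the ring, so a single step cannot separate those two parts of the change. From the compounds shown here alone, how an amine or a carboxylic acid on this ring would read in this assay remains open, as does whether the step carries over to other cores.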